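Dichlorobenzyl Variant of a Thiazole Ester Series

This account rests on a few compounds, and the source may have more. Where it says the series, first, only, none or still open, it means among the compounds named here.

Measured compounds:
Compound 1, `CCOC(=O)c1sc(-c2ccccc2)nc1N1CCC(NCc2ccccc2)CC1`: 11.7%
Compound 2, `CCOC(=O)c1sc(-c2ccccc2)nc1N1CCC(NCc2ccc(OC)cc2)CC1`: 8.4%
Compound 3, `CCOC(=O)c1sc(-c2ccccc2)nc1N1CCC(NCc2ccc(C(F)(F)F)cc2)CC1`: 22.7%

In an ADME assay on RAW264.7 cells (Mus musculus) for cytotoxicity, read by MTT assay, with a stated time of 72 h, tested at 50 uM (on this read-out higher numbers stand for more inhibition at the one concentration tested (going by the name of the read-out) and lower numbers for less inhibition), compound 1 gives 11.7%, the second highest of the three numbers. Compound 2 is nearest to it, with a step of a number 3.3 percentage points lower from compound 1 to compound 2 (within the scatter), so the two cannot be told apart. Compound 3 stands furthest, with a step of a number 11 percentage points higher from compound 1 to compound 3 (beyond the scatter), and also rises from compound 2, with a step of a number 14.3 percentage points higher from compound 2 to compound 3 (beyond the scatter).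

Compound 4, `CCOC(=O)c1sc(-c2ccccc2)nc1N1CCC(NCc2ccc(Cl)cc2Cl)CC1`, has not yet been measured. It differs from compound 1 as 2,4-dichlorophenyl in place of phenyl on a saturated chain carbon bound to an amine nitrogen. For the measured compounds named here, no measured step adds chlorine to this ring, so the two substituent steps on the benzyl ring must serve as guides: the methoxy step from compound 1 to compound 2 stayed within the scatter, whereas the trifluoromethyl step from compound 1 to compound 3 rose modestly. Two chlorines on the same ring are a larger change than either single group, and the expectation leans toward a modest rise in this assay, of a size like a number 12.3 percentage points higher from compound 1 to compound 4 (beyond the scatter), though with wide uncertainty. Compound 4 is therefore estimated at 24%, with a range from 8% to 42%.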

Compound 4, a percentage reported as inhibition, at one concentration (the size of the read-out at that concentration, not a potency): 9.43%
Estimate against measurement, compound 4: 14.6 percentage points above; measured number inside the range.
By their numbers in this assay, from the lowest: compounds 2, 4 and 1 (each within the scatter of the next); then compound 3.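

In this assay, the larger ring on the saturated chain carbon bound to an amine nitrogen, with 8 heavy atoms entering where 6 leave, gives a number 2.3 percentage points lower from compound 1 to compound 4 (within the scatter) and so does not separate from the unsubstituted phenyl of the parent. The same ring in place of 4-methoxyphenyl gives a number 1 percentage points higher from compound 2 to compound 4 (within the scatter), which places compounds 1, 2 and 4 together as one group that cannot be told apart, although their rings carry no substituent, methoxy or two chlorines. Set against the 4-(trifluoromethyl)phenyl ring, it gives a number 13.3 percentage points lower from compound 3 to compound 4 (beyond the scatter), so among these four compounds only compound 3 stands apart, and compounds 2 and 4 go against any reading that substitution on this ring in general raises the number.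

From the compounds shown here alone, how a single chlorine, a nitrile, a carboxylic acid or a dimethylamino group on this ring would read in this assay remains open, as does the effect of moving the trifluoromethyl group elsewhere on the ring. Why compound 3 alone stands apart also remains open, and nothing available here speaks to that question.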